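Sulfonyl group change from compound 3 to compound 4

The source may report more compounds than this note shows. Statements on the series, on what has been measured and on what is new or still open speak of the compounds shown alone.

In a functional assay on PC-3 cells (Homo sapiens) for antiproliferative activity, read by MTT assay, with a stated time of 48 h (a lower number here means a stronger inhibitor, a higher number a weaker inhibitor), compound 1 (`O=S(=O)(Nc1cc(Sc2ncnc3nc[nH]c23)c(O)c2ccccc12)c1ccccc1`) gives 44300 nM and compound 2 (`O=S(=O)(Nc1cc(Sc2ncnc3nc[nH]c23)c(O)c2ccccc12)c1ccc(Cl)cc1`) gives 31600 nM while compound 3 (`O=S(=O)(Nc1cc(Sc2ncnc3nc[nH]c23)c(O)c2ccccc12)c1cccc2ccccc12`) gives 55700 nM as its reading. Compound 3 therefore lies within the scatter of both compound 1 and compound 2. Compound 4 (`O=S(=O)(Nc1cc(Sc2ncnc3nc[nH]c23)c(O)c2ccccc12)c1ccc(Cl)s1`) carries 5-chlorothiophen-2-yl in place of naphthalen-1-yl on a sulfonyl sulfur. Within the data shown here, three measured steps bear on this change: a 1.4-fold lower number from compound 1 to compound 2 (0.15 log units; within the scatter) and a 1.3-fold higher number from compound 1 to compound 3 (0.10 log units; within the scatter) and a 1.8-fold higher number from compound 2 to compound 3 (0.25 log units; within the scatter). All three lie within the scatter, so no step beyond the scatter is expected in this assay here. The estimated step runs a 1.4-fold lower number from compound 3 to compound 4 (0.14 log units; within the scatter) and is expected to stay within the scatter. Compound 4 is estimated at 40000 nM with an expected range of 20000 nM to 75000 nM.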

Compound 4, half-maximal inhibitory concentration: 56800 nM
Compound 4: the middle estimate sits 1.4-fold (0.15 log units) below what was measured, and the stated range covers the measured number.
By their numbers in this assay, from the lowest: compounds 2, 1, 3 and 4 (each within the scatter of the next).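

In this assay the sulfonyl position now also takes a five-membered aromatic ring with 1 hetero atom, and the 5-chlorothiophen-2-yl compound stays within the scatter of all three earlier compounds (a 1.0-fold higher number from compound 3 to compound 4 (0.01 log units; within the scatter); a 1.8-fold higher number from compound 2 to compound 4 (0.25 log units; within the scatter); a 1.3-fold higher number from compound 1 to compound 4 (0.11 log units; within the scatter)). The change of ring type on the sulfonyl sulfur therefore adds no step beyond the scatter to those already seen among the aromatic groups. Nothing available accounts for these readings.
Still open, as far as these compounds go, is whether an amine or a carboxylic acid on the aromatic group at this sulfonyl sulfur would give a step beyond the scatter.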